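Working notes: fluoromethyl to hydroxymethyl on the chain

This account rests on a few compounds, and the source may have more. Where it says the series, first, only, none or still open, it means among the compounds named here.

Of the compounds shown here, two have been measured in a functional assay on HL-60 cells (Homo sapiens) for cytotoxicity, read by WST assay, with a stated time of 48 h; on this read-out higher numbers stand for weaker inhibition and lower numbers for stronger inhibition. Compound 1 `COc1cc(C(c2ccc(O)c(OC)c2)[C@H](C)[C@H](C)CF)ccc1O` gives 56000 nM. Compound 2 `COc1cc(C(c2ccc(O)c(OC)c2)[C@@H](C)[C@H](C)CF)ccc1O` gives 32000 nM, the lower of the two numbers, though the two values lie within the scatter of each other. Among the compounds with values here, the only step between them, a 1.8-fold lower number from compound 1 to compound 2 (0.24 log units; within the scatter), rests on the fact that compounds 1 and 2 differ only in the configuration as drawn and says nothing about substitution on the chain.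

Compound 3 `COc1cc(C(c2ccc(O)c(OC)c2)[C@@H](C)[C@@H](C)CO)ccc1O` is the next compound, not yet measured. It differs from compound 2 as follows: 1-(hydroxymethyl)ethyl in place of 1-(fluoromethyl)ethyl on a saturated chain carbon bound to two saturated chain carbons, the change being an exchange at the chain terminus, with 1-(hydroxymethyl)ethyl in place of 1-(fluoromethyl)ethyl. Within the data shown here, no measured step probes this exchange, so no direction beyond the scatter is expected from the numbers in hand. For compound 3 a value of 35000 nM is estimated, within 12000 nM to 100000 nM. The expected step is a 1.1-fold higher number from compound 2 to compound 3 (0.04 log units; within the scatter).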

Compound 3, half-maximal inhibitory concentration: > 100000 nM
Compound 3: a limit, no number; the forecaster's own chance of this, stated with the estimate: 10%; middle value at least 2.8-fold (0.45 log units) away from the limit.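

In this assay compound 3 gives > 100000 nM, which is a limit of the assay and not a number. Within the data shown here, the exchange of 1-(fluoromethyl)ethyl for 1-(hydroxymethyl)ethyl gives the first step beyond the scatter, an at least 3.1-fold higher number from compound 2 to compound 3 (0.49 log units; beyond the scatter), showing that this chain terminus can move the read-out towards weaker inhibition, while the other comparison, an at least 1.7-fold higher number from compound 1 to compound 3 (0.25 log units; that floor lies within the scatter), has a floor within the scatter. Both steps are floors only, and their true size stays unread for this reason: the limit of > 100000 nM in this assay, at which 1 of the 3 values shown sits.

Compound 3 is the only 1-(hydroxymethyl)ethyl compound shown, so how configuration acts alongside that group remains open. Also open, as far as these compounds go, is how an amine, a carboxylic acid or a longer chain at this terminus would read against 1-(fluoromethyl)ethyl.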